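This account rests on a few compounds, and the source may have more. Where it says the series, first, only, none or still open, it means among the compounds named here.

Compound 3 `CCCn1c(=O)[nH]c2nc(-c3ccc(S(=O)(=O)N4CCN(Cc5cccc(C)c5)CC4)cc3)[nH]c2c1=O` stands lowest of the three compounds measured in an assay on CHO cells for displacement of a labelled ligand from adenosine receptor A3 (Homo sapiens), read by scintillation counting, with a stated time of 45 min, tested at 1 uM, in the presence of a further agent that is not named here (on this read-out higher numbers stand for more inhibition at the one concentration tested (going by the name of the read-out) and lower numbers for less inhibition), where compound 3 gives 17%. Compound 2 `CCCn1c(=O)[nH]c2nc(-c3ccc(S(=O)(=O)N4CCN(c5ccc(Br)cc5)CC4)cc3)[nH]c2c1=O` gives 29% and compound 1 `CCCn1c(=O)[nH]c2nc(-c3ccc(S(=O)(=O)N4CCN(c5ccc(F)cc5)CC4)cc3)[nH]c2c1=O` gives 38%; the steps of a number 21 percentage points lower from compound 1 to compound 3 (beyond the scatter) and a number 12 percentage points lower from compound 2 to compound 3 (beyond the scatter) both lie beyond the scatter, while a number 9 percentage points lower from compound 1 to compound 2 (within the scatter) lies within it. Compound 4 `CCCn1c(=O)[nH]c2nc(-c3ccc(S(=O)(=O)N4CCN(Cc5cccc(Br)c5)CC4)cc3)[nH]c2c1=O` differs from compound 3 by bromo in place of methyl on an aromatic carbon. Going by the values given here, the only measured step touching a halogen on an aromatic carbon, a number 9 percentage points lower from compound 1 to compound 2 (within the scatter), was within the scatter, and no measured step exchanges a methyl for a bromo, so no change beyond the scatter is expected. The expected step is a number 1 percentage points higher from compound 3 to compound 4 (within the scatter). Compound 4 is therefore estimated at 18%, within a range from 5% to 32%.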

Compound 4, a percentage reported as inhibition, at one concentration (the size of the read-out at that concentration, not a potency): 23%
Compound 4: middle estimate off by 5 percentage points, on the low side; low and high end bracket the measured number.
By their numbers in this assay, from the lowest: compounds 3, 4, 2 and 1 (each within the scatter of the next, the first and the last beyond it).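

In this assay, the step of a number 6 percentage points higher from compound 3 to compound 4 (within the scatter) shows that 3-methylbenzyl and 3-bromobenzyl cannot be told apart at this place, so methyl and bromo, each a single heavy atom, read alike here. The 3-bromobenzyl of compound 4 also stays close to the 4-bromophenyl group, with the step of a number 6 percentage points lower from compound 2 to compound 4 (within the scatter), while the step of a number 15 percentage points lower from compound 1 to compound 4 (beyond the scatter) separates it from the 4-fluorophenyl group. From the compounds shown here alone, whether an amine or a carboxylic acid on this aromatic carbon would move the number remains open. Nothing available gives a reason for these steps.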